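A few compounds are considered here, and "the series" means these few. Any claim that something is new, unique, unknown or untested is made for them only; others in the source may bear on it.

- Compound 1 `O=C(Nc1ccc(-c2ccncc2)cc1)C1CCCN(Cc2ccc(F)c(F)c2)C1`: 600 nM
- Compound 2 `O=C(Nc1ccc(-c2ncc[nH]2)cc1)C1CCCN(Cc2ccc(F)c(F)c2)C1`: 19000 nM

In a functional assay on A-375 cells (Homo sapiens) for antiproliferative activity (on this read-out higher numbers stand for weaker inhibition and lower numbers for stronger inhibition), compound 2 has the higher number of the two, at 19000 nM. Compound 3 `O=C(Nc1ccc(-c2ccn[nH]2)cc1)C1CCCN(Cc2ccc(F)c(F)c2)C1` has the same atoms joined differently, with 1H-pyrazol-5-yl in place of 1H-imidazol-2-yl on an aromatic carbon. Going by the values given here, only one measured step bears on this, the large 32-fold higher number from compound 1 to compound 2 (1.50 log units; beyond the scatter), which changed the group at this same place. Compound 2 stands at 19000 nM and compound 1 at 600 nM, so a partial move back towards lower numbers is expected, though one step is thin evidence. The expected change is a 3.2-fold lower number from compound 2 to compound 3 (0.50 log units; beyond the scatter). For compound 3 the estimated value is 6000 nM, with an expected range of 1500 nM to 25000 nM.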

Compound 3, half-maximal inhibitory concentration: 520 nM
For compound 3 the middle estimate is 12-fold (1.06 log units) above the measured one; measured number below the stated range.
By their numbers in this assay, from the lowest: compounds 3 and 1 (each within the scatter of the next); then compound 2.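

In this assay, rearranging the same atoms from 1H-imidazol-2-yl to 1H-pyrazol-5-yl gives a 37-fold lower number from compound 2 to compound 3 (1.56 log units; beyond the scatter), even though both groups have the same counts of hydrogen-bond donors and acceptors. At this place on the ring, the arrangement of the atoms therefore matters, not just their kind and number. The poor result for compound 2 also does not extend to every five-membered aromatic ring, as 1H-pyrazol-5-yl and pyridin-4-yl are level, with a 1.2-fold lower number from compound 1 to compound 3 (0.06 log units; within the scatter).

Nothing available explains why the two arrangements differ so sharply. On these data alone, it also remains open whether a different group here, such as a carboxylic acid or an amine, would perform like compound 3.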